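Fluorophenyl for Methoxyphenyl on a Histamine Agonist Acylguanidine

This account rests on a few compounds, and the source may have more. Where it says the series, first, only, none or still open, it means among the compounds named here.

The two measured compounds share a core carrying a urea-like acylguanidine and an aminothiazole; compound 1 `COc1ccc(C(C)NC(=O)/N=C(\N)NCCCc2sc(N)nc2C)cc1` bears a 4-methoxyphenyl group on the branched chain carbon, while compound 2 `CCCCCNC(=O)/N=C(\N)NCCCc1sc(N)nc1C` carries a plain pentyl chain in its place. In a functional assay on Right cardiac atrium for agonist activity at histamine H2 receptor (Cavia porcellus), with a stated time of 30 min, in the presence of a further agent that is not named here (on this read-out lower numbers stand for an effect already at smaller amounts and higher numbers for an effect only at larger amounts of compound), compound 1 gives 38 nM, which is the higher of the two numbers seen so far. In this assay, among the compounds with values here, compound 2 gives 5.75 nM, a lower number than compound 1 by a margin that lies beyond the usual scatter; no single-point step between these two is drawn here, so only their two values are compared.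

Compound 3 `Cc1nc(N)sc1CCCN/C(N)=N/C(=O)NC(C)c1cccc(F)c1` has not yet been measured. It differs from compound 1 by 3-fluorophenyl in place of 4-methoxyphenyl on a saturated chain carbon bound to an amide-type nitrogen and a saturated chain carbon. Within the data shown here, nothing among the measured compounds shows what an aromatic ring substituent of this kind does on this read-out, so the expectation rests on compound 1 alone. Compound 3 is expected to stay close to compound 1, with a step of a 1.3-fold lower number from compound 1 to compound 3 (0.10 log units; within the scatter) that is estimated to fall within the scatter in either direction. For compound 3 an estimate of 30 nM is given, expected to lie between 10 nM and 100 nM.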

Compound 3, half-maximal effective concentration: 26.3 nM
Compound 3: middle estimate off by 1.1-fold (0.06 log units), on the high side; the measured number falls inside the stated range.
By their numbers in this assay, from the lowest: compound 2; then compounds 3 and 1 (each within the scatter of the next).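

Putting 3-fluorophenyl in place of 4-methoxyphenyl on a saturated chain carbon bound to an amide-type nitrogen and a saturated chain carbon gives, in this assay, a 1.4-fold lower number from compound 1 to compound 3 (0.16 log units; within the scatter), so this position accepts the exchange without a difference that can be told from repeat scatter. The hydrogen-bond acceptor counted in 4-methoxyphenyl is absent from 3-fluorophenyl, yet the two compounds stand within the scatter of each other, so for this pair that acceptor is not needed to keep a number of this size. No measurement at hand accounts for the two groups reading alike.

The exchange alters both the ring substituent and its numbering on the ring at once, so this one pair cannot separate what each contributes on this read-out. On these data alone, how an unsubstituted phenyl ring, or a phenyl ring carrying an amine or a carboxylic acid, would read at this position remains open, and so does whether any substituent on the ring can move the number beyond the scatter.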